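This account rests on a few compounds, and the source may have more. Where it says the series, first, only, none or still open, it means among the compounds named here.

Measured so far in a functional assay on HL-60 cells (Homo sapiens) for antiproliferative activity, with a stated time of 72 h (a lower number here means a stronger inhibitor, a higher number a weaker inhibitor), for three compounds:
- compound 1 `OC[C@H]1O[C@@H](n2cnc3c(NCc4ccc(Br)cc4)ncnc32)[C@H](O)[C@@H]1O` gives 47400 nM
- compound 2 `Cc1cccc(CNc2ncnc3c2ncn3[C@@H]2O[C@H](CO)[C@@H](O)[C@H]2O)c1` gives 6400 nM
- compound 3 `OC[C@H]1O[C@@H](n2cnc3c(NCc4ccc(Cl)cc4Cl)ncnc32)[C@H](O)[C@@H]1O` gives 96300 nM

Compound 3 has the highest number of the three, with compound 1 nearest and compound 2 furthest. Next in view is compound 4 `OC[C@H]1O[C@@H](n2cnc3c(NCc4c(F)ccc(F)c4F)ncnc32)[C@H](O)[C@@H]1O`, which has 2,3,6-trifluorophenyl in place of 2,4-dichlorophenyl on a saturated chain carbon bound to a nitrogen on an aromatic ring. The relevant evidence is the change of this same group among the measured compounds: a 2.0-fold higher number from compound 1 to compound 3 (0.31 log units; beyond the scatter) (modest), a 15-fold higher number from compound 2 to compound 3 (1.18 log units; beyond the scatter) (large) and a 7.4-fold lower number from compound 1 to compound 2 (0.87 log units; beyond the scatter) (modest). This group alone can therefore move the number widely, but no measured compound carries fluorine, so the direction for compound 4 is not directly shown. Compound 3 sits at the top with 96300 nM as its value, and compound 1, the other halogen-bearing compound with a single halogen, gives 47400 nM as its value. A modest move to a lower number is therefore expected in this assay with wide uncertainty. The step expected is a 2.8-fold lower number from compound 3 to compound 4 (0.44 log units; beyond the scatter) in this estimate. For compound 4 the estimated value is 35000 nM with an expected range from 9000 nM to 120000 nM as its bounds.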

Compound 4, half-maximal inhibitory concentration: 13000 nM
Beside the measured number, compound 4's estimate is 2.7-fold (0.43 log units) above it; the measured number falls inside the stated range.
By their numbers in this assay, from the lowest: compound 2; then compound 4; then compound 1; then compound 3.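

In this assay, the first fluorine-bearing group on a saturated chain carbon bound to a nitrogen on an aromatic ring gives a 7.4-fold lower number from compound 3 to compound 4 (0.87 log units; beyond the scatter) and a 3.6-fold lower number from compound 1 to compound 4 (0.56 log units; beyond the scatter), so among these compounds a halogen on the phenyl does not by itself bring a number as high as those of compound 1 and compound 3. Compound 2, whose 3-methylphenyl carries no halogen, keeps the lowest number, with a 2.0-fold higher number from compound 2 to compound 4 (0.31 log units; beyond the scatter), so the 2,3,6-trifluorophenyl of compound 4 lies closer to the methyl-bearing group than to either the 4-bromophenyl or the 2,4-dichlorophenyl. No measurement shown here accounts for this order of the four groups.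

The 2,3,6-trifluorophenyl differs from the other groups in both its halogen and its pattern of substitution, so the contribution of each remains unresolved, and a 4-fluorophenyl or a 2,4-difluorophenyl would help to separate them. Also open, from the compounds shown here alone, is how this position responds to a phenyl bearing an amine or a carboxylic acid, and to a longer chain in place of the single saturated carbon.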